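Dimethylamino in Place of Phenoxy: An Expected Cell Result

A few compounds are considered here, and "the series" means these few. Any claim that something is new, unique, unknown or untested is made for them only; others in the source may bear on it.

Measured so far in a functional assay on HOP-92 cells (Homo sapiens) for inhibition, read by sulforhodamine B assay, with a stated time of 48 h; a lower number here means that less compound is tolerated, a higher number that more compound is tolerated:
- compound 1, `COc1cc(C)cc(-c2c(-c3ccnc(-c4ccc(C(C)=O)cc4)c3)cnn2CC#N)c1`, gives > 100000 nM, which is a limit of the assay and not a number.
- compound 2, `COc1cc(C)cc(-c2nn(CC#N)cc2-c2ccc(-c3cccc(C(C)=O)c3)nc2)c1`, gives > 100000 nM, again a limit of the assay rather than a number.
- compound 3, `Cc1cc(O)cc(-c2nn(CC#N)cc2-c2ccnc(-c3ccc(Oc4ccccc4)cc3)c2)c1`, gives 39500 nM.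

Within the data shown here, compound 3 therefore stands as the only compound with an actual number in this assay; the two other values sit at the limit, as summarised by the limit of > 100000 nM in this assay, at which 2 of the 3 values shown sit. Among the measured compounds shown here, no pair among the measured compounds differs in a single place, so no measured step exists to lean on.

The next compound, compound 4, `Cc1cc(O)cc(-c2nn(CC#N)cc2-c2ccnc(-c3ccc(N(C)C)cc3)c2)c1`, differs from compound 3 in one place: dimethylamino in place of phenoxy on an aromatic carbon. The rest of the shared core, the nitrile-bearing chain and the hydroxyl-bearing ring stay the same.

With no measured step of this kind in the series, there is no basis to expect a change beyond the usual scatter of this assay in either direction. The step from compound 3 to compound 4 is therefore estimated as a 1.0-fold higher number from compound 3 to compound 4 (0.01 log units; within the scatter), essentially flat. On that basis compound 4 is expected to give about 40000 nM in this assay, with a plausible range from 15000 nM to 100000 nM.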

Compound 4, concentration lethal to 50% of the cells: > 100000 nM
Compound 4 was reported as a limit (the forecaster's own chance of this, stated with the estimate: 25%); middle value at least 2.5-fold (0.39 log units) away from the limit.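

Among these compounds, this is the first measured step, and it shows that the group at this place, on an aromatic carbon para to a large group, is not interchangeable: in this assay, replacing phenoxy with dimethylamino gives an at least 2.5-fold higher number from compound 3 to compound 4 (0.40 log units; beyond the scatter). The change swaps a group of 7 heavy atoms with a six-membered aromatic ring for one of 3 heavy atoms with no ring, while each has 0 hydrogen-bond donors, 1 hydrogen-bond acceptor and no net charge, so those counts do not separate the two compounds. The true size of the step stays unknown, and only its lower bound can be read, because compound 4 sits at a limit of the assay and not at a number: the limit of > 100000 nM in this assay, at which 3 of the 4 values shown sit.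

The compounds shown leave open whether losing the aromatic ring of phenoxy or bringing in the dimethylamino nitrogen matters more, and no cause for the step can be assigned from them. A methoxy group, which keeps the oxygen but has no ring, or an anilino group, which keeps a ring but has nitrogen in place of oxygen, at the same place would help separate those two possibilities.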